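The source may report more compounds than this note shows. Statements on the series, on what has been measured and on what is new or still open speak of the compounds shown alone.

Values in an ADME assay on microsomes from liver (Mus musculus) for metabolic stability; a higher number here means faster removal of the compound, a lower number slower removal:

- Compound 1 `COc1cc(OC)c(NC(=O)Cc2nn(CC(=O)O)c(=O)c3ccccc23)cc1Cl`: < 55 mL/min/kg, a limit
- Compound 2 `C[C@@H](C(=O)O)c1nn(Cc2cn3cc(OCC4CC4)c(Cl)cc3n2)c2ccccc2c1=O`: < 55 mL/min/kg, a limit

Neither entry is a number, so the two compounds cannot be ordered. In this assay, compound 2 stands at the limit of < 55 mL/min/kg in this assay, at which 2 of the 2 values shown sit.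

Compound 3 `CCC(C(=O)O)c1nn(Cc2cn3cc(OCC4CC4)c(Cl)cc3n2)c2ccccc2c1=O` has not yet been measured. It differs from compound 2 by 1-carboxypropyl in place of 1-carboxyethyl on an aromatic carbon, on a six-membered aromatic ring with 2 nitrogen (1-carboxypropyl in place of 1-carboxyethyl on an aromatic carbon). Within the data shown here, no measured pair differs in one place, so no direct precedent exists for this change. A shift beyond the scatter is not expected in this assay, and no direction is favoured. The expected change is a step that the limit leaves unreadable from compound 2 to compound 3. For compound 3, the estimated clearance is 40 mL/min/kg, with an expected range of 20 mL/min/kg to 65 mL/min/kg.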

Compound 3, clearance: < 56.7 mL/min/kg
Compound 3: a limit, no number; the forecaster's own chance of this, stated with the estimate: 70%; the middle value is on the limit's open side.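

In this assay compound 3 gives < 56.7 mL/min/kg, a limit. Among these compounds, with compound 2 also a limit at < 55 mL/min/kg, no step between compound 2 and compound 3 can be read. The compounds shown leave open whether 1-carboxypropyl in place of 1-carboxyethyl alters clearance at all.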